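Chloro in place of methoxy: compound 3 to compound 4

A few compounds are considered here, and "the series" means these few. Any claim that something is new, unique, unknown or untested is made for them only; others in the source may bear on it.

Measured so far:
compound 1 `CC(=O)N1CCN(c2cccc(-c3cc(Cl)c4c(N)ncnn34)c2C)C(=O)C1(C)C`: 84%
compound 2 `CC(=O)N1CCN(c2cc(-c3cc(Cl)c4c(N)ncnn34)ccc2C(F)(F)F)C(=O)C1(C)C`: 95%
compound 3 `COc1ccc(-c2cc(Cl)c3c(N)ncnn23)cc1N1CCN(C(C)=O)C(C)(C)C1=O`: 94%

In an ADME assay on microsomes from liver (Homo sapiens) for metabolic stability, read by LC-MS, using NADPH, with stated times of 6 min and 10 min, tested at 0.5 uM (on this read-out higher numbers stand for a more stable compound and lower numbers for a less stable compound), compound 3 gives 94%, within the scatter of compound 2 at 95% and of compound 1 at 84%. The next compound to be read is compound 4 `CC(=O)N1CCN(c2cc(-c3cc(Cl)c4c(N)ncnn34)ccc2Cl)C(=O)C1(C)C`, which carries chloro in place of methoxy on an aromatic carbon. Within the data shown here, no measured pair shows this exchange directly. The closest evidence is a number 1 percentage points lower from compound 2 to compound 3 (within the scatter), with methoxy in place of trifluoromethyl on an aromatic carbon, and that step lies within the scatter. Compound 1 differs from the others in more than one place and offers no single-change comparison. On this one small step, no change beyond the scatter is expected in this assay. The expected step is a number 2 percentage points lower from compound 3 to compound 4 (within the scatter), which would stay within the scatter. Compound 4 is estimated at 92%, with an expected range of 84% to 99%.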

Compound 4, percent of the compound remaining: 85%
Compound 4: middle estimate off by 7 percentage points, on the high side, and the stated range covers the measured number.
By their numbers in this assay, from the lowest: compounds 1, 4, 3 and 2 (each within the scatter of the next, the first and the last beyond it).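

In this assay, the aromatic carbon ortho to a large group and para to a large group now has three groups to compare: trifluoromethyl, methoxy and chloro. Chloro in place of methoxy gives a number 9 percentage points lower from compound 3 to compound 4 (within the scatter) and chloro in place of trifluoromethyl gives a number 10 percentage points lower from compound 2 to compound 4 (within the scatter) so that neither exchange moves the read-out beyond the scatter, and no group among these three stands apart at this position. Nothing at hand accounts for the size of either step.

Open is whether an amine, a carboxylic acid or a longer alkoxy chain on this carbon would also stay within the scatter of these compounds in this assay. Also open, from the compounds shown here alone, is whether the three groups would compare in the same way with a different group in place of the acetyl on the shared core.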